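The source may hold more compounds than are shown below. What is called first, only, known or untested is meant among the compounds shown, and "the series" means these compounds.

Of the compounds shown here, two have so far been tested in a functional assay on MCF7 cells (Homo sapiens) for cytotoxicity, read by MTT assay, with a stated time of 72 h; a higher number here means a weaker inhibitor, a lower number a stronger inhibitor. Compound 2 `O=C(Nc1ccc(Oc2ccnc3[nH]ccc23)c(F)c1)c1nn(-c2ccccc2)ccc1=O` gives 34900 nM in this assay, and compound 1 `COc1ccc(-n2ccc(=O)c(C(=O)Nc3ccc(Oc4ccnc5[nH]ccc45)c(F)c3)n2)cc1` gives 55400 nM. Going by the values given here, the step of a 1.6-fold lower number from compound 1 to compound 2 (0.20 log units; within the scatter) lies within the scatter, so these two numbers cannot be told apart; compound 2 simply holds one of two close values, with no other compound to place it against.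

Compound 3 `O=C(Nc1ccc(Oc2ccnc3[nH]ccc23)c(F)c1)c1nn(-c2ccc(Br)cc2F)ccc1=O` is the next compound, and it differs from compound 2 by 4-bromo-2-fluorophenyl in place of phenyl on an aromatic nitrogen. Among the compounds with values here, the only measured step, from compound 1 to compound 2, concerns a change on that same phenyl group, and it was small, within the scatter. Within the data shown here, there is no measured step that swaps in a 4-bromo-2-fluorophenyl group, so nothing in the data shows whether bromine and fluorine on this ring move the number. On that basis compound 3 is expected to stay close to compound 2, with a step of a 1.2-fold lower number from compound 2 to compound 3 (0.07 log units; within the scatter) that need not exceed the scatter. The estimate for compound 3 in this assay is therefore 30000 nM, with a range from 9000 nM to 100000 nM.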

Compound 3, half-maximal inhibitory concentration: 23500 nM
Compound 3: middle estimate off by 1.3-fold (0.11 log units), on the high side; measured number inside the range.
By their numbers in this assay, from the lowest: compounds 3, 2 and 1 (each within the scatter of the next, the first and the last beyond it).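

In this assay, adding a bromine and a fluorine to the phenyl ring on the aromatic nitrogen gives a 1.5-fold lower number from compound 2 to compound 3 (0.17 log units; within the scatter), so 4-bromo-2-fluorophenyl and plain phenyl cannot be told apart at this position. Set against 4-methoxyphenyl, the same group gives a 2.4-fold lower number from compound 1 to compound 3 (0.37 log units; beyond the scatter), the first step at this position to pass the scatter, although it is only a modest one, so swapping these substituted rings has so far not produced a large shift in the number. Nothing available here explains why these groups compare as they do.

Compound 3 changes two ring positions at once, so the compounds shown leave open what the bromine and the fluorine each contribute, and whether either alone would give a number like that of compound 2. From the compounds shown here alone, all three compounds also keep an aromatic carbon ring on this nitrogen, so it remains open whether a saturated group such as cyclohexyl, a longer alkyl chain, or a phenyl ring carrying an amine or a carboxylic acid would move the number further.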